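Adding a Methoxy Group to the Most Potent Compound

The source may report more compounds than this note shows. Statements on the series, on what has been measured and on what is new or still open speak of the compounds shown alone.

The three measured compounds share one core and differ in the group attached to its ring nitrogen. Compound 1 `CCOC(=O)CNn1c(C)nc2ccccc2c1=O` carries a short ester-bearing chain, compound 2 `Cc1nc2ccccc2c(=O)n1Nc1cc2ccccc2oc1=O` a larger ring-bearing group, and compound 3 `Cc1nc2ccccc2c(=O)n1NC(=O)/C(Cl)=C/c1ccccc1` an amide built on a chlorine-bearing double bond that ends in a phenyl ring. In a functional assay on NCI-H460 cells (Homo sapiens) for inhibition, read by sulforhodamine B assay, with a stated time of 48 h (on this read-out lower numbers stand for stronger inhibition of growth and higher numbers for weaker inhibition of growth), compound 1 gives 22600 nM, compound 2 gives 17300 nM and compound 3 gives 20 nM, the lowest of the three numbers and separated from both others by gaps far beyond the scatter.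

Compound 4 `COc1ccc(/C=C(\Cl)C(=O)Nn2c(C)nc3ccccc3c2=O)cc1` differs from compound 3 in a single place: methoxy in place of hydrogen on an aromatic carbon. For the measured compounds named here, no pair of measured compounds shows this change, so nothing here tells how it acts. The expectation is a small step from compound 3 to compound 4, not clearly beyond the scatter in either direction. Compound 4 is therefore estimated at 30 nM, with a range from 8 nM to 120 nM, which means an expected step of a 1.5-fold higher number from compound 3 to compound 4 (0.18 log units; within the scatter).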

Compound 4, concentration for 50% growth inhibition: 600 nM
Beside the measured number, compound 4's estimate is 20-fold (1.30 log units) below it; measured number outside the range, above it.
By their numbers in this assay, from the lowest: compound 3; then compound 4; then compounds 2 and 1 (each within the scatter of the next).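

In this assay, placing methoxy on the aromatic carbon para to a large group gives a 30-fold higher number from compound 3 to compound 4 (1.48 log units; beyond the scatter). For the compounds shown here, a change of only 2 heavy atoms is therefore enough to move the number far beyond the scatter, so this position on the phenyl ring is not indifferent to what it carries, something the earlier compounds could not show. No supporting data on hand bear on why the number rises, so the reason stays unknown.

From the compounds shown here alone, it remains open whether this step belongs to methoxy itself or would come with any group on this carbon; fluorine, hydroxyl or methyl in the same place would help separate those readings. Going by these compounds, it is equally open whether methoxy on another carbon of this ring would give a similar step.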